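A few compounds are considered here, and "the series" means these few. Any claim that something is new, unique, unknown or untested is made for them only; others in the source may bear on it.

Measured in an ADME assay on the whole organism (Rattus norvegicus, strain Sprague-Dawley) for pharmacokinetics, using cassette dosing, at a dose of 1 mg/kg by the oral route; on this read-out lower numbers stand for lower oral bioavailability and higher numbers for higher oral bioavailability:
- compound 1 `O=C(Nc1ccc2[nH]c(=O)oc2c1)C(=O)N1CCN(c2ccc(C(F)(F)F)cc2)CC1`: 24.8%
- compound 2 `O=C(Nc1ccc2[nH]c(=O)oc2c1)C(=O)N1CCN(c2ccc(F)c(F)c2)CC1`: 13%
- compound 3 `O=C(Nc1ccc2[nH]c(=O)oc2c1)C(=O)N1CCN(c2ccc(Cl)c(F)c2)CC1`: 28.2%

Compound 3 shares the top of this short series. The values show a number 3.4 percentage points higher from compound 1 to compound 3 (within the scatter), set against a number 15.2 percentage points higher from compound 2 to compound 3 (beyond the scatter).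

Compound 4 `O=C(Nc1ccc2[nH]c(=O)oc2c1)C(=O)N1CCN(c2ccc(C(F)(F)F)c(F)c2)CC1` keeps the fluoro group and the rest of compound 3 but carries trifluoromethyl in place of chloro on an aromatic carbon. Among the measured compounds shown here, no measured step makes exactly this exchange. The nearest evidence is compound 1, which already carries trifluoromethyl but lacks the fluoro group, and there the data show a number 3.4 percentage points higher from compound 1 to compound 3 (within the scatter). The larger shift, a number 15.2 percentage points higher from compound 2 to compound 3 (beyond the scatter), shows that the group leaving here can matter, but it involves fluoro rather than trifluoromethyl. In this assay, a step no larger than the scatter is therefore expected, with no firm direction. The estimated step is a number 2.2 percentage points lower from compound 3 to compound 4 (within the scatter). For compound 4 the expected value is 26%, with an estimated range from 13% to 40%.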

Compound 4, oral bioavailability: 8.7%
The estimate for compound 4 lay 17.3 percentage points above the measured number; measured number below the stated range.
By their numbers in this assay, from the lowest: compounds 4 and 2 (each within the scatter of the next); then compounds 1 and 3 (each within the scatter of the next).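

In this assay, trifluoromethyl in place of chloro on this aromatic carbon, ortho to a fluoro group, gives a number 19.5 percentage points lower from compound 3 to compound 4 (beyond the scatter) and so is far from neutral when that fluoro group is present. Fluoro in place of hydrogen on the trifluoromethyl compound likewise gives a number 16.1 percentage points lower from compound 1 to compound 4 (beyond the scatter), whereas trifluoromethyl in place of fluoro gives a number 4.3 percentage points lower from compound 2 to compound 4 (within the scatter), leaving that pair within the scatter of each other. Nothing available explains the drop seen with this combination of groups.

From the compounds shown here alone, what a methoxy group or a nitrile would do on this aromatic carbon, with the fluoro group kept, remains open. It is also open why chloro stands apart here, since fluoro and trifluoromethyl in this place give values within the scatter of each other.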